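Compound 3: hydroxy replaces diethylamino on the side chain

The source may report more compounds than this note shows. Statements on the series, on what has been measured and on what is new or still open speak of the compounds shown alone.

Values in a functional assay on K562 cells (Homo sapiens) for antiproliferative activity, read by MTT assay, with a stated time of 48 h; a lower number here means a stronger inhibitor, a higher number a weaker inhibitor:
compound 1 `CCCn1c(N)c(-c2nc3ccccc3[nH]2)c2nc(C#N)c(C#N)nc21`: > 50000 nM (a limit, not a number)
compound 2 `CCN(CC)CCCn1c(N)c(-c2nc3ccccc3[nH]2)c2nc(C#N)c(C#N)nc21`: 1800 nM

For the measured compounds named here, compound 2, at 1800 nM, carries the only actual number in this assay so far. The next structure is compound 3 `N#Cc1nc2c(-c3nc4ccccc4[nH]3)c(N)n(CCCO)c2nc1C#N`, and the change from compound 2 is hydroxy in place of diethylamino on a saturated chain carbon, three bonds along the chain from an aromatic nitrogen: hydroxy in place of diethylamino, which reads in full as 3-(diethylamino)propyl to 3-hydroxypropyl.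

Going by the values given here, one measured step bears on this place on the chain: an at least 27-fold lower number from compound 1 to compound 2 (1.44 log units; beyond the scatter). That step is large and beyond the scatter, and it comes with diethylamino in place of hydrogen. Among the compounds with values here, compound 3 gives up the same diethylamino, but no measured compound carries hydroxy, so the size of the reversal is uncertain. A higher number in this assay is expected, beyond the scatter, going part of the way or all the way back towards compound 1. The expected change is a 10-fold higher number from compound 2 to compound 3 (1.00 log units; beyond the scatter). For compound 3 the estimated value is 18000 nM, with an expected range of 5000 nM to 50000 nM.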

Compound 3, half-maximal inhibitory concentration: > 50000 nM
Compound 3 gave a limit, no number; the forecaster's own chance of this, stated with the estimate: 35%; middle value at least 2.7-fold (0.44 log units) away from the limit.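

Exchanging 3-(diethylamino)propyl for 3-hydroxypropyl gives an at least 27-fold higher number from compound 2 to compound 3 (1.44 log units; beyond the scatter) in this assay, so this position on the chain now has a second measured replacement for diethylamino, and hydroxy does not keep the activity seen with diethylamino. Among the three chain ends shown, only the diethylamino of compound 2 gives an actual number in this assay, and neither hydrogen nor hydroxy does so; this holds for these three compounds only. Compound 1 and compound 3 cannot be ordered against each other, and the step between them cannot be read: the limit of > 50000 nM in this assay, at which 2 of the 3 values shown sit.

The compounds shown leave open whether the gain depends on an amine nitrogen at the chain end as such, or on the particular diethylamino group, which a primary amine, dimethylamino, piperidine or morpholine at the same place would help to separate, with a carbon-only end such as a pentyl chain as a further comparison. Also open, on these data alone, are the length of the chain that carries the diethylamino group, through a 2-(diethylamino)ethyl or a longer chain, and how a carboxylic acid at this place would read.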